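Working notes: aryl swap on the sulfonyl sulfur

A few compounds are considered here, and "the series" means these few. Any claim that something is new, unique, unknown or untested is made for them only; others in the source may bear on it.

Measured so far in a functional assay on SW-620 cells (Homo sapiens) for antiproliferative activity, read by MTT assay, with a stated time of 72 h; on this read-out higher numbers stand for weaker inhibition and lower numbers for stronger inhibition:
Compound 1 `Cc1ccc(S(=O)(=O)NCc2cn(C[C@H](O)[C@H]3OC(=O)C(OCc4ccccc4)=C3OCc3ccccc3)nn2)cc1` gives 45800 nM.
Compound 2 `O=C1O[C@H]([C@@H](O)Cn2cc(-c3cccc(O)c3)nn2)C(OCc2ccccc2)=C1OCc1ccccc1` gives > 100000 nM, which is a limit of the assay.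
Compound 3 `O=C1O[C@H]([C@@H](O)Cn2cc(-c3cc(F)cc(F)c3)nn2)C(OCc2ccccc2)=C1OCc1ccccc1` gives > 100000 nM, which is a limit of the assay.

Going by the values given here, compound 1 carries the only number in this assay; the other two values sit at the limit of > 100000 nM in this assay, at which 2 of the 3 values shown sit. The measured steps, an at least 2.1-fold higher number from compound 1 to compound 2 (0.33 log units; beyond the scatter) and an at least 2.1-fold higher number from compound 1 to compound 3 (0.33 log units; beyond the scatter), both exchange the whole (((4-methylphenyl)sulfonyl)amino)methyl group for an aryl group, so neither touches the aryl on the sulfonyl sulfur and neither bears directly on the change to compound 4. Compound 4 `O=C1O[C@H]([C@@H](O)Cn2cc(CNS(=O)(=O)c3ccc(Cl)cc3F)nn2)C(OCc2ccccc2)=C1OCc1ccccc1` differs from compound 1 by 4-chloro-2-fluorophenyl in place of 4-methylphenyl on a sulfonyl sulfur. Among the compounds with values here, with no measured step of this kind, no step beyond the scatter is expected: a 1.1-fold lower number from compound 1 to compound 4 (0.06 log units; within the scatter). Compound 4 is therefore estimated at 40000 nM, within 15000 nM to 100000 nM.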

Compound 4, half-maximal inhibitory concentration: 42400 nM
Beside the measured number, compound 4's estimate is 1.1-fold (0.03 log units) below it; measured number inside the range.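

In this assay, exchanging the aryl group on the sulfonyl sulfur gives a 1.1-fold lower number from compound 1 to compound 4 (0.03 log units; within the scatter), so this position accepts 4-chloro-2-fluorophenyl in place of 4-methylphenyl with no readable change. Compound 1 and compound 4, which both keep the sulfonamide, carry numbers, while compound 2 and compound 3, which lack it, each sit at a limit: the limit of > 100000 nM in this assay, at which 2 of the 4 values shown sit.

Going by these compounds, whether any group on the sulfonyl sulfur moves the number beyond the scatter remains open. A methyl group or a phenyl ring carrying an amine would test whether an aryl group without halogens or a non-aromatic group behaves the same way.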